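Compound 4 in the Histamine Receptor Binding Series

The source may report more compounds than this note shows. Statements on the series, on what has been measured and on what is new or still open speak of the compounds shown alone.

Measured so far:
- compound 1 `CN1CCc2ccc(OCCCN3CCCCC3)cc2C1=O`: 23 nM
- compound 2 `CCN1CCN(CCCOc2ccc3c(c2)C(=O)N(C)CC3)CC1`: 1100 nM
- compound 3 `CN1CCN(CCCOc2ccc3c(c2)C(=O)N(C)CC3)CC1`: 706 nM

All three share one core and differ only in the amine at the end of the chain. In an assay on cerebellum for displacement of a labelled ligand from histamine H1 receptor (Cavia porcellus), read by scintillation counting, with a stated time of 60 min (on this read-out lower numbers stand for stronger inhibition and higher numbers for weaker inhibition), compound 3 gives 706 nM, the second highest number of the three; compound 2 sits within the scatter of it, while compound 1 lies far below, with a 31-fold higher number from compound 1 to compound 3 (1.49 log units; beyond the scatter) and a 48-fold higher number from compound 1 to compound 2 (1.68 log units; beyond the scatter) showing how much the piperazine rings raised the number relative to piperidin-1-yl.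

Compound 4 `CCN(CC)CCCOc1ccc2c(c1)C(=O)N(C)CC2` is not yet measured. Its change from compound 3 is diethylamino in place of 4-methylpiperazin-1-yl on a saturated chain carbon, three bonds along the chain from an oxygen on an aromatic ring. Going by the values given here, the ring with two hetero atoms leaves and an open-chain amine enters, so the steps that bear on it are the two large piperidine-to-piperazine steps, now partly run backwards. A substantial fall in the number is therefore expected for compound 4 in this assay, roughly a 12-fold lower number from compound 3 to compound 4 (1.07 log units; beyond the scatter), though not necessarily all the way to compound 1. The estimate for compound 4 is 60 nM, with a range from 15 nM to 300 nM.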

Compound 4, inhibition constant: 542 nM
Estimate against measurement, compound 4: 9.0-fold (0.96 log units) below; measured number above the stated range.
By their numbers in this assay, from the lowest: compound 1; then compounds 4, 3 and 2 (each within the scatter of the next, the first and the last beyond it).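

In this assay, swapping the ring with two hetero atoms for open-chain diethylamino at this position does not bring the number down to that of compound 1: there is a 1.3-fold lower number from compound 3 to compound 4 (0.11 log units; within the scatter), and only a 2.0-fold lower number from compound 2 to compound 4 (0.31 log units; beyond the scatter). The distance from piperidin-1-yl remains wide, with a 24-fold higher number from compound 1 to compound 4 (1.37 log units; beyond the scatter), so this step is of the same large kind as the two piperazine steps. At this position, then, the piperazine rings are not the only amines far from piperidin-1-yl, and among these four compounds only compound 1 gives a low number.

As far as these compounds go, it remains open whether another ring amine, such as pyrrolidin-1-yl or morpholin-4-yl, on the same chain would stand with compound 1 or with the other three. Nothing available here gives a reason for the gap between piperidin-1-yl and the other amines.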